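From 4-fluorophenyl to furan-2-yl at the growth-inhibition limit

This account rests on a few compounds, and the source may have more. Where it says the series, first, only, none or still open, it means among the compounds named here.

In a functional assay on MDA-MB-231 cells (Homo sapiens) for inhibition, read by CCK-8 assay, with a stated time of 48 h (a lower number here means a stronger inhibitor of growth, a higher number a weaker inhibitor of growth), compound 1 `CN1CCN(c2ccc(Nc3ncc(Cl)c(NCc4ccc(C(F)(F)F)cc4)n3)nc2)CC1` gives 19100 nM. Compound 2 `CN1CCN(c2ccc(Nc3ncc(Cl)c(NCc4ccc(F)cc4)n3)nc2)CC1` gives > 100000 nM, which is a limit of the assay and not a number. From the compounds shown here alone, compound 2 therefore stands at the limit of > 100000 nM in this assay, at which 1 of the 2 values shown sits, and its true position is unknown.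

Compound 3 `CN1CCN(c2ccc(Nc3ncc(Cl)c(NCc4ccco4)n3)nc2)CC1` differs from compound 2 by furan-2-yl in place of 4-fluorophenyl on a saturated chain carbon bound to a nitrogen on an aromatic ring.

Within the data shown here, only one measured step bears on this change, and only indirectly. With fluoro in place of trifluoromethyl on an aromatic carbon, the reading moved by an at least 5.2-fold higher number from compound 1 to compound 2 (0.71 log units; beyond the scatter). That step altered a substituent and did not exchange the ring itself, so it gives no direct size for the present swap. No strong gain is therefore expected, and compound 3 should remain in the weak region of this assay, with no change beyond the scatter expected. The expected step, loosely estimated, is an at least 1.1-fold lower number from compound 2 to compound 3 (0.04 log units; that floor lies within the scatter). For compound 3 the estimated value is 90000 nM, with an expected range from 30000 nM to 250000 nM.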

Compound 3, concentration for 50% growth inhibition: 11000 nM
Beside the measured number, compound 3's estimate is 8.2-fold (0.91 log units) above it, and the stated range ends above it.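

On the saturated chain carbon bound to a nitrogen on an aromatic ring, the benzene ring is not required for a measurable reading in this assay, since furan-2-yl in place of 4-fluorophenyl gives an at least 9.0-fold lower number from compound 2 to compound 3 (0.95 log units; beyond the scatter). From the compounds shown here alone, the value of compound 2 is a limit of the assay and not a number, so that step has only a floor and its true size remains unknown: the limit of > 100000 nM in this assay, at which 1 of the 3 values shown sits. The other step at this place, furan-2-yl in place of 4-(trifluoromethyl)phenyl, gives a 1.7-fold lower number from compound 1 to compound 3 (0.24 log units; within the scatter), so a five-membered aromatic ring with 1 hetero atom and a para-free reading of the larger trifluoromethyl-bearing group cannot be told apart here, and among the three groups only 4-fluorophenyl sits at the limit.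

The compounds shown leave open whether the reading at this place depends on an aromatic ring at all, as a saturated cyclohexyl group would test, and whether thiophen-2-yl or pyridin-3-yl would behave as furan-2-yl does. They also leave open how a longer chain between the nitrogen and the ring would read, and whether any group here can reach much lower numbers than the two measured values.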